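The source may hold more compounds than are shown below. What is called first, only, known or untested is meant among the compounds shown, and "the series" means these compounds.

Compound 1 `O=C1/C(=C\c2cccc(Oc3ccccc3)c2)c2ccccc2N1c1c(Cl)cccc1Cl` and compound 2 `O=C1/C(=C\c2ccccc2[N+](=O)[O-])c2ccccc2N1c1c(Cl)cccc1Cl` share one core and part ways only in the group on the exocyclic double bond. In a functional assay on HuTu80 cells (Homo sapiens) for cytotoxicity, read by MTT assay, with a stated time of 72 h (a lower number here means that less compound is needed, a higher number that more compound is needed for the effect), compound 1 gives 10 ug/mL, and compound 2 gives 10 ug/mL, which stands level with compound 1 within the scatter. Compound 3 `O=C1/C(=C\c2cccc(Cl)c2)c2ccccc2N1c1c(Cl)cccc1Cl` differs from compound 2 by 3-chlorophenyl in place of 2-nitrophenyl on a double-bonded chain carbon bound to a double-bonded ring carbon. Going by the values given here, no step between two measured compounds is available for this change, so the expectation rests on the two level values alone. For compound 3 the expected step is no change at the digits printed from compound 2 to compound 3 (within the scatter), nothing beyond the scatter in either direction. Compound 3 is therefore estimated at 10 ug/mL, with a range from 4 ug/mL to 25 ug/mL.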

Compound 3, concentration for half-maximal effect: 7 ug/mL
Compound 3: the middle estimate sits 1.4-fold (0.15 log units) above what was measured; the measured number falls inside the stated range.
By their numbers in this assay, from the lowest: compounds 3, 1 and 2 (each within the scatter of the next).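

In this assay, 3-chlorophenyl in place of 2-nitrophenyl on a double-bonded chain carbon bound to a double-bonded ring carbon gives a 1.4-fold lower number from compound 2 to compound 3 (0.15 log units; within the scatter) and chloro in place of phenoxy on an aromatic carbon gives a 1.4-fold lower number from compound 1 to compound 3 (0.15 log units; within the scatter) as well. At this position, the 3-chlorophenyl group therefore stands level with both earlier groups, so this third group also does not separate the compounds. No measurement here explains this closeness. Going by these compounds, it remains open whether an amine or a carboxylic acid on this phenyl ring, or a longer alkyl chain in its place, would move the number beyond the scatter.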